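Azide for Propyl on the Amide Chain of Compound 2

The source may hold more compounds than are shown below. What is called first, only, known or untested is meant among the compounds shown, and "the series" means these compounds.

The series shares a core carrying three methoxy groups on one ring and a benzylic link to a second ring. Compound 1 `COc1ccc(CNc2cc(OC)c(OC)c(OC)c2)cc1[N+](=O)[O-]` and compound 3 `COc1ccc(CNc2cc(OC)c(OC)c(OC)c2)cc1Cl` hold a secondary amine at that link; in a functional assay on KYSE-450 cells (Homo sapiens) for inhibition, read by MTT assay, with a stated time of 48 h (a lower number here means a stronger inhibitor, a higher number a weaker inhibitor), compound 1 gives 16800 nM, while compound 3 gives 47800 nM, the step of a 2.8-fold higher number from compound 1 to compound 3 (0.45 log units; beyond the scatter) being the only one measured in this set. Compound 2 `CCCCC(=O)N(Cc1ccc(OC)c(O)c1)c1cc(OC)c(OC)c(OC)c1` carries a butylcarbonyl group on the linking nitrogen and a hydroxy in place of the nitro or chloro, and in this assay compound 2 gives 300 nM, the lowest of the three numbers and beyond the scatter from both others.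

Compound 4 `COc1ccc(CN(C(=O)CN=[N+]=[N-])c2cc(OC)c(OC)c(OC)c2)cc1O` is derived from compound 2 by a change on the acyl chain: azido in place of propyl on a saturated chain carbon bound to a carbonyl carbon. Among the compounds with values here, no measured step touches this chain; the one measured step concerns an aromatic substituent on a different part of the molecule, so it gives no guide to the size or direction here. The expectation therefore rests mainly on compound 2 giving 300 nM with the amide intact, and a step of a 2.3-fold higher number from compound 2 to compound 4 (0.37 log units; beyond the scatter) is estimated, with wide uncertainty. Compound 4 is expected to give about 700 nM, in a range from 120 nM to 4000 nM.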

Compound 4, half-maximal inhibitory concentration: 160 nM
Beside the measured number, compound 4's estimate is 4.4-fold (0.64 log units) above it, and the stated range covers the measured number.
By their numbers in this assay, from the lowest: compounds 4 and 2 (each within the scatter of the next); then compound 1; then compound 3.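

In this assay, within the data shown here, the step of a 1.9-fold lower number from compound 2 to compound 4 (0.27 log units; within the scatter) is the first reading at this position, a saturated chain carbon bound to a carbonyl carbon, and it places the two compounds within the scatter of each other. The exchange of propyl for azido keeps the same count of heavy atoms but replaces all three carbons with nitrogens, adds two double bonds outside aromatic rings and brings in a hydrogen-bond acceptor, and none of this separates the two compounds in this read-out. So, within this single pair, the acyl chain at this position need not be an all-carbon one for the number to stay at the level of compound 2, and the data shown offer no explanation for this result.

The compounds shown leave open whether an amine, a carboxylic acid or a longer chain at this position would also stay within the scatter of compound 2 in this assay. They also leave open what the butylcarbonyl group on the linking nitrogen contributes on its own, as no pair shown differs in that one place.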